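Removing the sugar from the hydroxyethyl-triazole urea series

A few compounds are considered here, and "the series" means these few. Any claim that something is new, unique, unknown or untested is made for them only; others in the source may bear on it.

Compound 1 `O=C(Nc1ccc(-n2cc(CCO[C@H]3O[C@@H](CO)[C@H](O)[C@@H]3O)nn2)cc1)Nc1ccccc1C(F)(F)F` carries a 3,4-dihydroxy-5-(hydroxymethyl)oxolan-2-yl group on the oxygen of its hydroxyethyl chain. In an assay on isolated protein for inhibition of ATP-dependent RNA helicase DDX3X (Homo sapiens), read by FRET, with stated times of 30 s and 40 min (on this read-out lower numbers stand for stronger inhibition and higher numbers for weaker inhibition), compound 1 gives "not active" (no number reported), so no number is known for it and its standing on the scale cannot be placed. Two other members of the series do give numbers: in this assay compound 2 `CCCCc1cn(-c2ccc(NC(=O)Nc3cc(CCC(C)=O)ccc3C)cc2)nn1` gives 2490 nM, and in this assay compound 3 `CCOP(=O)(OCC)OCCc1cn(-c2ccc(NC(=O)Nc3ccccc3C)cc2)nn1` gives 890 nM. Among the measured compounds shown here, neither is a one-place neighbour of compound 1, so no step is counted from them.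

Compound 4 `O=C(Nc1ccc(-n2cc(CCO)nn2)cc1)Nc1ccccc1C(F)(F)F` is compound 1 with the change (hydrogen in place of 3,4-dihydroxy-5-(hydroxymethyl)oxolan-2-yl on an oxygen on a saturated carbon), that is, hydrogen in place of 3,4-dihydroxy-5-(hydroxymethyl)oxolan-2-yl on an oxygen on a saturated carbon. Since compound 1 has no number, the size of the step cannot be computed; the expectation is that compound 4 returns a measurable value, in the direction of stronger inhibition relative to an inactive parent, because compound 3 with a different group on the same chain gives 890 nM. Compound 4 is estimated at 2500 nM, with a range from 600 nM to 10000 nM, and a real chance remains that only an inactive result is reported.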

Compound 4, half-maximal inhibitory concentration: 11200 nM
Beside the measured number, compound 4's estimate is 4.5-fold (0.65 log units) below it; measured number above the stated range.
By their numbers in this assay, from the lowest: compound 3; then compound 2; then compound 4.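

No step can be read from compound 1 to compound 4: in this assay compound 1 gives "not active" (no number reported), while compound 4 gives 11200 nM. No measurement bearing on a cause for this result is at hand. Left open is how groups other than 2-hydroxyethyl at this place would read on the unchanged core of compound 4.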